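This account rests on a few compounds, and the source may have more. Where it says the series, first, only, none or still open, it means among the compounds named here.

Of the compounds shown here, three have been measured in a functional assay on K562 cells (Homo sapiens) for cytotoxicity, read by sulforhodamine B assay, with a stated time of 48 h, tested at 0.1 uM; on this read-out lower numbers stand for a stronger effect and higher numbers for a weaker effect at the one concentration tested. Compound 1 `COc1cc(-c2cc(/C=C/C(=O)c3ccc(N)cc3)[nH]n2)cc(OC)c1OC` gives 94% there. Compound 2 `COc1ccc(-c2cc(/C=C/C(=O)c3ccc(N)cc3)[nH]n2)cc1OC` gives 98%. Compound 3 `COc1cc(C(=O)/C=C/c2cc(-c3cc(OC)c(OC)c(OC)c3)n[nH]2)cc(OC)c1OC` gives 104%. Between compound 1 and compound 2 the change is hydrogen in place of methoxy on an aromatic carbon, and it produced a number 4 percentage points higher from compound 1 to compound 2 (within the scatter). Compound 3 carries a different core from compound 1; the difference between the two cores is not broken down here.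

Compound 4 `COc1ccc(-c2cc(/C=C/C(=O)c3cc(OC)c(OC)c(OC)c3)[nH]n2)cc1OC` has not yet been measured. It differs from compound 3 by hydrogen in place of methoxy on an aromatic carbon, the same change as that from compound 1 to compound 2, in the same surroundings. For compound 4 an expected step of a number 1 percentage points higher from compound 3 to compound 4 (within the scatter) is estimated, resting on the pair compound 1 and compound 2, where a number 4 percentage points higher from compound 1 to compound 2 (within the scatter). Compound 4 is therefore expected to give about 105%, estimated to lie between 93% and 116%.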

Compound 4, a percentage reported as activity, at one concentration (the size of the read-out at that concentration, not a potency): 94%
Compound 4: middle estimate off by 11 percentage points, on the high side, within the range that was stated.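

In this assay, putting hydrogen in place of methoxy gave a number 10 percentage points lower from compound 3 to compound 4 (within the scatter), so neither this step nor the earlier one can be told apart from no change at all. Set side by side, the two steps do not differ by more than repeated measurements would be expected to: the same change on two cores in this assay, a number 4 percentage points higher (within the scatter) from compound 1 to compound 2 and a number 10 percentage points lower (within the scatter) from compound 3 to compound 4, 14 percentage points apart, within the scatter of two such steps. This gives no sign that the change acts differently on the two cores, but it does not prove that it acts alike, and it offers no firm basis for carrying a step from one core to the other.

The compounds shown leave open what a carboxylic acid or a longer chain such as ethoxy would do in place of that methoxy. They also leave open how these compounds behave at any higher concentration.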